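A few compounds are considered here, and "the series" means these few. Any claim that something is new, unique, unknown or untested is made for them only; others in the source may bear on it.

Both measured compounds sit at the edge of what an assay for binding affinity to adenosine receptor A1 (Bos taurus) (on this read-out lower numbers stand for stronger inhibition and higher numbers for weaker inhibition), can report. Compound 1 `Cc1ccc2c(O)c(C(=O)OCc3ccccc3)cnc2n1` gives > 10000 nM in this assay, which is a limit of the measurement rather than a number. Compound 2 `CC(=O)Nc1ccc2c(O)c(C(=O)NCc3ccccc3)cnc2n1` gives > 10000 nM in this assay, again a limit and not a measured value. On the numbers shown, compound 2 therefore stands at the limit of > 10000 nM in this assay, at which 2 of the 2 values shown sit, and nothing separates it from compound 1.

Compound 3 `O=C(NCc1ccccc1)c1cnc2ncccc2c1O` differs from compound 2 in one place: hydrogen in place of acetamido on an aromatic carbon, in words hydrogen in place of acetamido on an aromatic carbon. Among the compounds with values here, no step between two measured compounds exists here, so the effect of this kind of change has not been seen in this assay. The step is expected to be a step that the limit leaves unreadable from compound 2 to compound 3, that is, no move beyond the scatter, because compound 2 rests at the limit of > 10000 nM in this assay, at which 2 of the 2 values shown sit, and nothing shown points toward stronger binding after the change. For compound 3 the estimate in this assay is 15000 nM, with a range from 5000 nM to 50000 nM, and a limit rather than a number is again the most likely report.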

Compound 3, inhibition constant: 2750 nM
Compound 3: middle estimate off by 5.5-fold (0.74 log units), on the high side, and the stated range ends above it.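

In this assay, replacing the acetamido group with hydrogen on an aromatic carbon next to the ring nitrogen gives an at least 3.6-fold lower number from compound 2 to compound 3 (0.56 log units; beyond the scatter), so what sits at this position can change binding to the receptor. Within the data shown here, the change also gives the first reading that is a real number rather than a limit, with compound 3 at 2750 nM, which offers a measured starting point for later comparisons. The size of the step can only be stated as a minimum because compound 2 is recorded only as a limit and not as a number: the limit of > 10000 nM in this assay, at which 2 of the 3 values shown sit.

This single pair cannot tell whether binding improves because acetamido is gone or because of the hydrogen itself, since the change removes four heavy atoms, including a hydrogen-bond donor and a hydrogen-bond acceptor, all at once. It also leaves open how a simple amine, a methoxy group or a chlorine atom on the same carbon would compare with hydrogen and acetamido, and whether any such group would bring a further change in binding.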